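A few compounds are considered here, and "the series" means these few. Any claim that something is new, unique, unknown or untested is made for them only; others in the source may bear on it.

Measured so far:
compound 1 `CC(C)C[C@@H](NC(=S)Nc1ccccc1)c1nc2ccccc2[nH]1`: 12100 nM
compound 2 `CC(C)C[C@H](NC(=S)Nc1ccccc1)c1nc2ccccc2[nH]1`: 29100 nM

In a functional assay on HeLa cells (Homo sapiens) for cytotoxicity, read by MTT assay (on this read-out lower numbers stand for stronger inhibition and higher numbers for weaker inhibition), compound 1 gives 12100 nM and compound 2 gives 29100 nM. Compound 1 thus stands at the lower of the two numbers. Going by the values given here, the only step known is a 2.4-fold higher number from compound 1 to compound 2 (0.38 log units; beyond the scatter); it rests on the fact that compounds 1 and 2 differ only in the configuration as drawn and carries no information about the side chain.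

Compound 3 `CC(C)[C@@H](NC(=S)Nc1ccccc1)c1nc2ccccc2[nH]1` is not yet measured in this assay. It differs from compound 1 by isopropyl in place of isobutyl on a saturated chain carbon bound to an amide-type nitrogen and an aromatic carbon. Among the compounds with values here, no measured step touches this position: the one known step concerns configuration alone, so nothing sets a direction for the change of chain. The default expectation is a step within the scatter, with the range kept wide. Compound 3 is therefore estimated at 15000 nM, between 6000 nM and 40000 nM. The step from compound 1 is expected to be a 1.2-fold higher number from compound 1 to compound 3 (0.09 log units; within the scatter).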

Compound 3, half-maximal inhibitory concentration: "not active" (no number reported)
The entry for compound 3 holds no number; the estimate stays without a comparison.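

Going by these compounds alone, compound 3 is recorded only as "not active", with no number, so no step from compound 1 to compound 3 can be read. The compounds shown leave open how far isopropyl in place of isobutyl shifts the read-out, and nothing available bears on this result.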